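This account rests on a few compounds, and the source may have more. Where it says the series, first, only, none or still open, it means among the compounds named here.

Working notes on the series. Compound 1 `CC(C)n1ncc2c(C(=O)NCc3cn(-c4cccc(Br)c4)nn3)cccc21` and compound 2 `Cc1ccccc1-n1cc(CNC(=O)c2cccc3c2cnn3C(C)C)nn1` share one core and differ only in the group on the aromatic nitrogen. In a functional assay on MGC-803 cells (Homo sapiens) for inhibition, read by MTT assay, with a stated time of 72 h (a higher number here means a weaker inhibitor, a lower number a stronger inhibitor), compound 1 gives only the limit of > 40000 nM. In this assay compound 2 likewise gives only the limit of > 40000 nM. The step that the two limits leave unreadable from compound 1 to compound 2 therefore has no readable size, and compound 2 stands at the limit together with every value shown, as the limit of > 40000 nM in this assay, at which 2 of the 2 values shown sit, records. Compound 3 `CC(C)n1ncc2c(C(=O)NCc3cn(-c4ccc(C(F)(F)F)cc4)nn3)cccc21` carries 4-(trifluoromethyl)phenyl in place of 2-methylphenyl on an aromatic nitrogen. Going by the values given here, no measured step bears on this change, since the single step known is unreadable, so for this assay no direction can be taken from the data and the change is expected to give nothing beyond the scatter. Compound 3 is expected to sit at 45000 nM, in the range 15000 nM to 120000 nM, in this assay. The expected step that the limit leaves unreadable from compound 2 to compound 3 is accordingly estimated as none beyond the scatter.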

Compound 3, half-maximal inhibitory concentration: > 40000 nM
Compound 3: no number, only a limit (the forecaster's own chance of this, stated with the estimate: 75%); the middle value is on the limit's open side.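

Compound 1, compound 2 and compound 3 all give only a limit in this assay, and no step between them can be read: the limit of > 40000 nM in this assay, at which 3 of the 3 values shown sit.

The compounds shown leave open whether any group on the aromatic nitrogen of the shared core gives a readable number in this assay.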